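Swapping methyl for methylsulfonyl in compound 2

A few compounds are considered here, and "the series" means these few. Any claim that something is new, unique, unknown or untested is made for them only; others in the source may bear on it.

Compound 1 (`COc1cc(CNc2cc(Br)cc3[nH]ncc23)c([N+](=O)[O-])cc1OC`) gives 6110 nM
Compound 2 (`Cc1ccc(CNc2cc(C(F)(F)F)cc3[nH]ncc23)c([N+](=O)O)c1`) gives 1340 nM
Compound 3 (`O=[N+]([O-])c1ccc(Cl)cc1CNc1cc(C(F)(F)F)cc2[nH]ncc12`) gives 490 nM

In a functional assay on H22 cells (Mus musculus) for inhibition, read by MTT assay, with a stated time of 24 h (on this read-out higher numbers stand for weaker inhibition and lower numbers for stronger inhibition), compound 2 sits in the middle: its number is the second highest of the three, lower than that of compound 1 and higher than that of compound 3, and both gaps lie beyond the usual scatter. Compound 4 (`CS(=O)(=O)c1ccc(CNc2cc(C(F)(F)F)cc3[nH]ncc23)c([N+](=O)O)c1`) differs from compound 2 by having methylsulfonyl in place of methyl on an aromatic carbon. Within the data shown here, no measured pair shows this change alone, so the data offer no direct guide. Only a slight fall in the number is expected (a 1.3-fold lower number from compound 2 to compound 4 (0.13 log units; within the scatter)), which would stay within the scatter. Compound 4 is estimated at 1000 nM (range 300 nM to 3500 nM).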

Compound 4, half-maximal inhibitory concentration: > 20000 nM
Compound 4: no number, only a limit (the forecaster's own chance of this, stated with the estimate: 3%); middle value at least 20-fold (1.30 log units) from the limit.
By their numbers in this assay, from the lowest: compound 3; then compound 2; then compound 1. At a limit, above all of these: compound 4.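

In this assay, among these compounds, the aromatic carbon para to a large group proves far from indifferent to what it carries: methylsulfonyl in place of methyl gives an at least 14-fold higher number from compound 2 to compound 4 (1.17 log units; beyond the scatter), a large loss of inhibition that the earlier compounds gave no hint of. Compound 4 reaches only a limit of the assay, not a number, so the true size of this step stays unknown: the limit of > 20000 nM in this assay, at which 1 of the 4 values shown sits.

The compounds shown leave open how an amine, a nitrile or a carboxylic acid on this carbon would behave. From the compounds shown here alone, whether the same swap costs as much in other members also remains open.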